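Dropping One Chloro Group: Cytotoxicity Expected to Stay Unreadable

A few compounds are considered here, and "the series" means these few. Any claim that something is new, unique, unknown or untested is made for them only; others in the source may bear on it.

Compound 1 `CCOC(=O)CCCCCOc1cccc(CN(C(=O)c2ccc(-c3cc(OC)cc(OC)c3)cc2)C(C)C)c1`: > 26000 nM
Compound 2 `CCOC(=O)CCCCCOc1cccc(CN(C(=O)c2ccc(-c3cc(F)cc(OC)c3)cc2)C(C)C)c1`: > 26000 nM
Compound 3 `CCOC(=O)CCCCCOc1cccc(CN(C(=O)c2ccc(-c3ccc(Cl)c(Cl)c3)cc2)C(C)C)c1`: > 26000 nM

In an ADME assay on BJ cells (Homo sapiens) for cytotoxicity, read by CellTiter-Glo and resazurin assay, with a stated time of 72 h (on this read-out lower numbers stand for an effect already at smaller amounts and higher numbers for an effect only at larger amounts of compound), compound 3 gives only a limit, > 26000 nM, and not a number. Compound 1 likewise gives only a limit in this assay, > 26000 nM. Compound 2 also gives only a limit, > 26000 nM. The steps a step that the two limits leave unreadable from compound 1 to compound 2, a step that the two limits leave unreadable from compound 1 to compound 3 and a step that the two limits leave unreadable from compound 2 to compound 3 therefore cannot be sized, because of the limit of > 26000 nM in this assay, at which 3 of the 3 values shown sit.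

Compound 4 `CCOC(=O)CCCCCOc1cccc(CN(C(=O)c2ccc(-c3cccc(Cl)c3)cc2)C(C)C)c1` differs from compound 3 by hydrogen in place of chloro on an aromatic carbon. Going by the values given here, none of the measured steps gives a readable size for any change on this ring, so no direction beyond the scatter can be expected for the step in this assay. Compound 4 is therefore expected to sit at the limit as well, with an estimate of 40000 nM and a range from 20000 nM to 100000 nM. The estimated step that the limit leaves unreadable from compound 3 to compound 4 is expected to be small, within the scatter.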

Compound 4, half-maximal effective concentration: > 18400 nM
Compound 4 was reported as a limit; the forecaster's own chance of this, stated with the estimate: 85%; the middle value is on the limit's open side.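

Compound 4 gives only a limit in this assay, > 18400 nM, so its steps from compound 1, compound 2 and compound 3 cannot be read: the limit of > 18400 nM in this assay, at which 1 of the 4 values shown sits.

The compounds shown leave open how large an effect, if any, each of these single changes has on cytotoxicity in this assay.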